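One Carbon Longer on the Sulfonamide Nitrogen

The source may report more compounds than this note shows. Statements on the series, on what has been measured and on what is new or still open speak of the compounds shown alone.

For the measured compounds named here, in a physicochemical assay for lipophilicity (a higher number here means a more lipophilic compound, a lower number a more polar compound), compound 2 `CN(CCCn1cc[n+](C)c1/C=N/O)S(=O)(=O)c1ccccc1` gives -1.59, the lower of the two numbers measured so far. Compound 1 `CCN(CCCn1cc[n+](C)c1/C=N/O)S(=O)(=O)C(F)(F)F` gives -1.02 in this assay, higher by a margin beyond the scatter. Compound 3 `CCN(CCCn1cc[n+](C)c1/C=N/O)S(=O)(=O)c1ccccc1` has not been measured yet. It differs from compound 2 by methyl in place of hydrogen on a saturated chain carbon bound to a sulfonamide nitrogen, which cut one bond further out reads methyl to ethyl. Going by the values given here, no measured pair differs in only that way, so a rise of roughly the size of the scatter is expected, namely a number 0.29 log units higher from compound 2 to compound 3 (within the scatter). Compound 3 is accordingly estimated at -1.3, with a likely range from -1.7 to -0.9.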

Compound 3, distribution coefficient: -1.27
For compound 3 the middle estimate is 0.03 log units below the measured one, and the stated range covers the measured number.
By their numbers in this assay, from the lowest: compound 2; then compounds 3 and 1 (each within the scatter of the next).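

In this assay, for the compounds shown here, methyl in place of hydrogen on a saturated chain carbon bound to a sulfonamide nitrogen gives a number 0.32 log units higher from compound 2 to compound 3 (beyond the scatter) as the first reading of this change at this place. With ethyl held fixed, phenyl in place of trifluoromethyl on a sulfonyl sulfur gives a number 0.25 log units lower from compound 1 to compound 3 (within the scatter) and so does not separate the two compounds. Nothing available bears on why either step has this size.

As far as these compounds go, whether a longer chain such as propyl on the sulfonamide nitrogen would extend the step remains open. So does whether the same step holds with trifluoromethyl on the sulfonyl sulfur.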